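This account rests on a few compounds, and the source may have more. Where it says the series, first, only, none or still open, it means among the compounds named here.

Compound 1 `COc1ccc2c(=O)c(-c3cc(OC)c(OC)cc3OC)coc2c1` carries a methoxy group on the shared core, and in a functional assay on A-375 cells (Homo sapiens) for antiproliferative activity, read by MTT assay, with a stated time of 24 h (on this read-out higher numbers stand for weaker inhibition and lower numbers for stronger inhibition), compound 1 gives 2640 nM. Among the three compounds measured in this assay this is the highest number: compound 2 `COc1cc(OC)c(-c2coc3cc(OCc4ccccc4F)ccc3c2=O)cc1OC` gives 2100 nM, and compound 3 `COc1cc(OC)c(-c2coc3cc(OCc4cccc(F)c4)ccc3c2=O)cc1OC` gives 1300 nM. The step to compound 4 `COc1cc(OC)c(-c2coc3cc(OCc4ccc(Cl)cc4)ccc3c2=O)cc1OC` replaces a hydrogen on the same saturated chain carbon bound to an oxygen on an aromatic ring (4-chlorophenyl in place of hydrogen on a saturated chain carbon bound to an oxygen on an aromatic ring). Going by the values given here, two measured steps bear on this change, since each also replaces a hydrogen on that carbon: a 1.3-fold lower number from compound 1 to compound 2 (0.10 log units; within the scatter), and a 2.0-fold lower number from compound 1 to compound 3 (0.31 log units; beyond the scatter). The gap between those two outcomes, a 1.6-fold lower number from compound 2 to compound 3 (0.21 log units; within the scatter), is small. Among the compounds with values here, no measured step shows chlorine in place of fluorine on the entering ring, so the direction is taken from the steps to compound 2 and compound 3 alone. A modest lowering of the number is therefore expected for compound 4, on the scale of a 1.7-fold lower number from compound 1 to compound 4 (0.22 log units; within the scatter), with a real chance that it stays within the scatter. Compound 4 is estimated at 1600 nM in this assay, with a range from 800 nM to 3200 nM.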

Compound 4, half-maximal inhibitory concentration: 1020 nM
Compound 4: the middle estimate sits 1.6-fold (0.20 log units) above what was measured; low and high end bracket the measured number.
By their numbers in this assay, from the lowest: compounds 4, 3, 2 and 1 (each within the scatter of the next, the first and the last beyond it).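

With the 4-chlorophenyl group on the saturated chain carbon bound to an oxygen on an aromatic ring, this assay records a 2.6-fold lower number from compound 1 to compound 4 (0.41 log units; beyond the scatter), so a second entering ring, and the first carrying chlorine, moves the number beyond the scatter. The result also gives the first gap between two entering rings that passes the scatter, a 2.1-fold lower number from compound 2 to compound 4 (0.31 log units; beyond the scatter), showing that the choice of ring at this carbon can count, not merely its presence. Going by these compounds alone, by contrast, a 1.3-fold lower number from compound 3 to compound 4 (0.11 log units; within the scatter) does not allow compound 3 and compound 4 to be put in order, and compound 2 remains the one replacement whose step from compound 1 stays within the scatter. Nothing available accounts for these differences.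

As far as these compounds go, it remains open whether the identity of the halogen or its place on the entering ring sets the gaps among compound 2, compound 3 and compound 4. Also open, from the compounds shown here alone, is how an unsubstituted phenyl, a pyridine ring, or an amine or carboxylic acid on the entering ring would read in this assay.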